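The source may report more compounds than this note shows. Statements on the series, on what has been measured and on what is new or still open speak of the compounds shown alone.

Working notes on the series.

The series shares one core and varies the group on a saturated chain carbon bound to a carbonyl carbon and a double-bonded nitrogen. Compound 1 `COc1ccc2cc(C(C)C(=O)OCC(OC(C)=O)C(OC(C)=O)C(OC(C)=O)C(/C=N/CC(=O)O)OC(C)=O)ccc2c1` carries hydrogen there; in a physicochemical assay for pharmacokinetics, at pH 5 (a higher number here means that the compound lasts longer, a lower number that the compound disappears faster), compound 1 gives 88 h. Compound 2 `COc1ccc2cc(C(C)C(=O)OCC(OC(C)=O)C(OC(C)=O)C(OC(C)=O)C(/C=N/[C@@H](C)C(=O)O)OC(C)=O)ccc2c1` carries methyl, and in this assay compound 2 gives 77 h. Compound 3 `COc1ccc2cc(C(C)C(=O)OCC(OC(C)=O)C(OC(C)=O)C(OC(C)=O)C(/C=N/[C@H](C(=O)O)C(C)C)OC(C)=O)ccc2c1` carries isopropyl, and in this assay compound 3 gives 88 h. Compound 3 thus stands level with compound 1, and all three numbers lie within the scatter of one another: a 1.1-fold lower number from compound 1 to compound 2 (0.06 log units; within the scatter), no change at the digits printed from compound 1 to compound 3 (within the scatter), a 1.1-fold higher number from compound 2 to compound 3 (0.06 log units; within the scatter).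

Compound 4 `COc1ccc2cc(C(C)C(=O)OCC(OC(C)=O)C(OC(C)=O)C(OC(C)=O)C(/C=N/[C@@H](CS)C(=O)O)OC(C)=O)ccc2c1` is not yet measured. It differs from compound 3 by sulfanylmethyl in place of isopropyl on a saturated chain carbon bound to a carbonyl carbon and a double-bonded nitrogen. The measured steps that bear on it are those same three exchanges at this position, from hydrogen to methyl, hydrogen to isopropyl and methyl to isopropyl, none of which moved the half-life beyond the scatter. Nothing in the measured set tests a sulfanylmethyl group, so the expectation rests on the position alone. For compound 4 the step is expected to be a 1.1-fold lower number from compound 3 to compound 4 (0.03 log units; within the scatter), no change beyond the scatter. In this assay compound 4 is therefore estimated at 82 h, with a range from 45 h to 150 h.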

Compound 4, half-life: 77 h
Beside the measured number, compound 4's estimate is 1.1-fold (0.03 log units) above it, and the stated range covers the measured number.
By their numbers in this assay, from the lowest: compounds 2, 4, 1 and 3 (each within the scatter of the next).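

For the compounds shown here, the sulfanylmethyl group is the only group at this position that carries sulfur, a hydrogen-bond donor and a hydrogen-bond acceptor, yet in this assay exchanging it for isopropyl (a 1.1-fold lower number from compound 3 to compound 4 (0.06 log units; within the scatter)) or for hydrogen (a 1.1-fold lower number from compound 1 to compound 4 (0.06 log units; within the scatter)) stays within the scatter. Read one bond further out, sulfanyl in place of hydrogen on a saturated chain carbon, two bonds along the chain from a carbonyl carbon and a double-bonded nitrogen, also leaves the half-life unmoved (no change at the digits printed from compound 2 to compound 4 (within the scatter)), so all four compounds now lie within the scatter of one another and no compound in the series goes against this. The data in hand offer no explanation for this flat picture.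

From the compounds shown here alone, whether the position stays this flat with a charged or larger group, such as an amine, a carboxylic acid, a phenyl ring or a longer chain, remains open. Also open, going by these compounds, is whether the half-life stays equally insensitive to this position at any pH other than the one tested here.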